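The compounds below may be only part of what the source reports. "The series", "measured", "known", "first", "only" and "open" are said of these compounds alone.

In a functional assay on MCF7 cells (Homo sapiens) for antiproliferative activity, read by MTT assay, with a stated time of 48 h (on this read-out lower numbers stand for stronger inhibition and higher numbers for weaker inhibition), compound 3 `C#CCCOC(=O)c1ccc(C(CC)(CC)c2ccc(OCCC(O)(CC)CC)c(C)c2)n1CC` gives > 50000 nM, which is a limit of the assay and not a number. Compound 1 `CCN(CC)CCNC(=O)c1ccc(C(CC)(CC)c2ccc(OCCC(O)(CC)CC)c(C)c2)n1CC` gives 550 nM, and compound 2 `CCn1c(C(=O)NCCN)ccc1C(CC)(CC)c1ccc(OCCC(O)(CC)CC)c(C)c1` gives 670 nM. Compound 4 `CCn1c(C(=O)N(C)CC(=O)O)ccc1C(CC)(CC)c1ccc(OCCC(O)(CC)CC)c(C)c1` changes compound 3 on the carbonyl carbon, with (carboxymethyl)(methyl)amino in place of (but-3-yn-1-yl)oxy on a carbonyl carbon. Like compounds 1 and 2, compound 4 has a nitrogen on that carbon. The nearest evidence is two large steps, an at least 90-fold higher number from compound 1 to compound 3 (1.95 log units; beyond the scatter) and an at least 74-fold higher number from compound 2 to compound 3 (1.87 log units; beyond the scatter), while the end of the chain mattered little in a 1.2-fold higher number from compound 1 to compound 2 (0.09 log units; within the scatter). For the measured compounds named here, no measured compound carries the carboxymethyl group, so only partial recovery is expected in this assay. The expected change is an at least 8.3-fold lower number from compound 3 to compound 4 (0.92 log units; beyond the scatter). For compound 4, the estimated value is 6000 nM, with an expected range from 800 nM to 50000 nM.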

Compound 4, half-maximal inhibitory concentration: 79 nM
Compound 4: middle estimate off by 76-fold (1.88 log units), on the high side; measured number outside the range, below it.
By their numbers in this assay, from the lowest: compound 4; then compounds 1 and 2 (each within the scatter of the next). At a limit, above all of these: compound 3.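

Compounds 1 and 2 tied a nitrogen on the carbonyl carbon to activity, and both carry a chain ending in an amine. Compound 4 shows that this amine end is not needed: (carboxymethyl)(methyl)amino gives a 7.0-fold lower number from compound 1 to compound 4 (0.84 log units; beyond the scatter) and an 8.5-fold lower number from compound 2 to compound 4 (0.93 log units; beyond the scatter), and compared with (but-3-yn-1-yl)oxy it gives an at least 630-fold lower number from compound 3 to compound 4 (2.80 log units; beyond the scatter). That last step is only a minimum, as compound 3 sits at a limit and not at a number: the limit of > 50000 nM in this assay, at which 1 of the 4 values shown sits.

The compounds shown leave open whether the gain comes from the carboxylic acid or from the methyl on the nitrogen. A methyl ester of the acid, or (carboxymethyl)amino without that methyl, would separate the two.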